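The source may hold more compounds than are shown below. What is called first, only, known or untested is meant among the compounds shown, and "the series" means these compounds.

Series notes. Three compounds have been run: compound 1 `COc1ncnc2c1c(-c1ccccc1)cn2[C@@H]1O[C@H](CO)[C@@H](O)[C@H]1O`, compound 2 `O=c1[nH]cnc2c1c(-c1ccsc1)cn2[C@@H]1O[C@H](CO)[C@@H](O)[C@H]1O` and compound 3 `Cc1ncnc2c1c(-c1ccsc1)cn2[C@@H]1O[C@H](CO)[C@@H](O)[C@H]1O`, all on the shared core. In a functional assay on HCT-116 cells (Homo sapiens), read by MTT assay, with a stated time of 72 h (a higher number here means a weaker inhibitor, a lower number a stronger inhibitor), compound 1 reaches only a limit of the assay, > 20000 nM, and not a number. Compound 2 likewise gives only a limit in this assay, > 20000 nM. Compound 3 gives a number in this assay, 1430 nM. Compound 2 thus stands at the limit of > 20000 nM in this assay, at which 2 of the 3 values shown sit, so its distance from compound 3 cannot be stated. Compound 4 `O=c1[nH]cnc2c1c(-c1ccco1)cn2[C@@H]1O[C@H](CO)[C@@H](O)[C@H]1O` differs from compound 2 by furan-2-yl in place of thiophen-3-yl on an aromatic carbon. Within the data shown here, no step between two measured compounds is available to set a size for this exchange, so the expectation rests on the position of compound 2 alone. The step expected is a step that the limit leaves unreadable from compound 2 to compound 4, that is none beyond the scatter, with compound 4 expected to remain at the limit in this assay. Compound 4 is accordingly estimated at 25000 nM, with a range from 5000 nM to 100000 nM.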

Compound 4, half-maximal inhibitory concentration: > 20000 nM
Compound 4 gave a limit, no number; the forecaster's own chance of this, stated with the estimate: 70%; the middle value is on the limit's open side.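

Compound 4 gives > 20000 nM in this assay, a limit and not a number. Compound 2 gives > 20000 nM, also a limit, so no step can be read between these two compounds. The compounds shown leave open whether furan-2-yl in place of thiophen-3-yl changes the value where a number is readable, as for compound 3 at 1430 nM.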